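A few compounds are considered here, and "the series" means these few. Any claim that something is new, unique, unknown or untested is made for them only; others in the source may bear on it.

Compound 1 `CC(=O)Nc1ccc(Cc2ccc(OCCN)cc2C)cc1`: in a functional assay on HEK293T cells for agonist activity at trace amine-associated receptor 1 (Mus musculus), read by BRET and cAMP accumulation (a higher number here means that more compound is needed for the effect, a lower number that less compound is needed), compound 1 gives > 10000 nM, a limit of the assay.
Compound 2 `CC(=O)NCCOc1ccc(Cc2ccc(NC(C)=O)cc2)c(C)c1`: in this assay compound 2 gives > 10000 nM, again a limit of the assay.

Compound 2 thus stands at the limit, as the limit of > 10000 nM in this assay, at which 2 of the 2 values shown sit, records. Within the data shown here, the single measured step, a step that the two limits leave unreadable from compound 1 to compound 2, cannot be read; both of its ends are limits. Compound 3 `CC(=O)Nc1ccc(Cc2ccc(OCCNC(=N)NC(=N)N)cc2C)cc1` differs from compound 2 by a group of 6 heavy atoms (2 carbon, 4 nitrogen; no ring) in place of a group of 3 heavy atoms (2 carbon, 1 oxygen; no ring), on an amine nitrogen. Among the measured compounds shown here, no measured step bears on this change, and nothing in the data points to a shift beyond the scatter in this assay. Compound 3 is expected to remain at the limit, estimated at 10000 nM with a range from 2000 nM to 50000 nM. The expected step is a number no higher from compound 2 to compound 3 (the limit leaves the size open).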

Compound 3, half-maximal effective concentration: > 10000 nM
Compound 3: a limit, no number; the forecaster's own chance of this, stated with the estimate: 70%; the middle value lies on the limit itself.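

In this assay compound 3 gives > 10000 nM, a limit of the assay. Among these compounds, no step among compound 1, compound 2 and compound 3 can be read. The compounds shown leave open whether any group on the amine nitrogen gives a measurable value.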